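A few compounds are considered here, and "the series" means these few. Any claim that something is new, unique, unknown or untested is made for them only; others in the source may bear on it.

In a functional assay on DU-145 cells (Homo sapiens) for cytotoxicity, read by MTT assay, with a stated time of 48 h (on this read-out lower numbers stand for stronger inhibition and higher numbers for weaker inhibition), compound 1 (`COc1ccc2c(c1)C(C)=CC(C)(C)N2Cc1cn(Cc2cc3cc(OC)ccc3nc2Cl)nn1`) gives 28600 nM. Under the same conditions, compound 2 (`CC1=CC(C)(C)N(Cc2cn(Cc3cc4ccccc4nc3Cl)nn2)c2ccccc21`) gives 19300 nM, and compound 3 (`CC1=CC(C)(C)N(Cc2cn(Cc3cc4ccc(C)cc4nc3Cl)nn2)c2ccccc21`) gives 27000 nM. The value of compound 1 lies within the usual scatter of both of the others, so the three numbers form a single group with no meaningful order among them.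

Compound 4 (`COc1ccc2nc(Cl)c(Cn3cc(CN4c5ccc(C)cc5C(C)=CC4(C)C)nn3)cc2c1`) differs from compound 1 in one place: methyl in place of methoxy on an aromatic carbon. This is methyl in place of methoxy on an aromatic carbon of a six-membered aromatic ring of carbon only, part of a fused or bridged system of two rings. Among the measured compounds shown here, no measured pair shows this exact exchange. For the measured compounds named here, the one measured step that bears on it is a 1.4-fold higher number from compound 2 to compound 3 (0.15 log units; within the scatter), and that step is methyl in place of hydrogen on an aromatic carbon, so it is only an indirect guide. With that step as the guide, no change beyond the scatter is expected in this assay, and the direction cannot be called with confidence. The estimated step is small: a 1.1-fold lower number from compound 1 to compound 4 (0.04 log units; within the scatter). For compound 4 the expected value is 26000 nM, with an estimated range from 14000 nM to 45000 nM.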

Compound 4, half-maximal inhibitory concentration: 19800 nM
Compound 4: middle estimate off by 1.3-fold (0.12 log units), on the high side, within the range that was stated.
By their numbers in this assay, from the lowest: compounds 2, 4, 3 and 1 (each within the scatter of the next).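

In this assay, the exchange at this aromatic carbon, meta to a fused ring and para to a fused ring, gives a 1.4-fold lower number from compound 1 to compound 4 (0.16 log units; within the scatter) and so stays within the scatter. Among the compounds shown here, this is the first direct reading of methyl against methoxy, since the only earlier step, a 1.4-fold higher number from compound 2 to compound 3 (0.15 log units; within the scatter), was a different exchange, methyl in place of hydrogen on an aromatic carbon. Compound 1 and compound 4 cannot be told apart here, so at this position the assay does not distinguish methoxy from methyl, and no measurement at hand offers an explanation for this result.

From the compounds shown here alone, with only methoxy and methyl compared at this carbon, it remains open whether a hydroxyl, an amine or a carboxylic acid there would give a number outside the scatter of compound 1. Going by these compounds, it is equally open whether a longer chain such as ethoxy or butoxy, or a single halogen such as fluorine, would keep the value of the compound within that same group.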